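One methoxy group fewer: an expectation for compound 4

A few compounds are considered here, and "the series" means these few. Any claim that something is new, unique, unknown or untested is made for them only; others in the source may bear on it.

In a functional assay on BT-549 cells (Homo sapiens) for cytotoxicity, read by sulforhodamine B assay, with a stated time of 48 h, tested at 0.01 uM (on this read-out higher numbers stand for a weaker effect at the one concentration tested and lower numbers for a stronger effect), compound 1 `COc1cc(-c2cc(/C=C/C(=O)c3ccc(N)cc3)[nH]n2)cc(OC)c1OC` gives 85%. In the same this assay compound 2 `COc1ccc(C(=O)/C=C/c2cc(-c3cc(OC)c(OC)c(OC)c3)n[nH]2)cc1OC` gives 95%, and compound 3 `COc1ccc(C(=O)/C=C/c2cc(-c3cc(OC)c(OC)c(OC)c3)n[nH]2)cc1` gives 97%. The cores of compound 1 and compound 2 differ in one place: 4-aminophenyl in place of 3,4-dimethoxyphenyl on a carbonyl carbon. Measured in this assay, this difference gives a number 10 percentage points higher from compound 1 to compound 2 (within the scatter). Compound 3 arises from compound 2 by a single change, (hydrogen in place of methoxy on an aromatic carbon), and this change gives a number 2 percentage points higher from compound 2 to compound 3 (within the scatter). The longer route shows a number 12 percentage points higher from compound 1 to compound 3 (beyond the scatter).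

Compound 4 `COc1ccc(-c2cc(/C=C/C(=O)c3ccc(N)cc3)[nH]n2)cc1OC` has not yet been measured. It arises from compound 1 by hydrogen in place of methoxy on an aromatic carbon. Among the compounds with values here, this is the same kind of change as the one that turns compound 2 into compound 3, although the surroundings are not identical: in compound 1 the aromatic carbon that loses the methoxy group is ortho to a methoxy group, meta to a large group and also meta to a methoxy group, whereas in compound 2 that carbon is ortho to a methoxy group and meta to a large group only. Because a number 2 percentage points higher from compound 2 to compound 3 (within the scatter) stayed within the scatter, the step from compound 1 to compound 4 is expected to be small as well, a number 2 percentage points higher from compound 1 to compound 4 (within the scatter). With that expectation, compound 4 is estimated at 87% in this assay, and four of five repeat measurements would be expected to fall between 75% and 98%.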

Compound 4, a percentage reported as activity, at one concentration (the size of the read-out at that concentration, not a potency): 84%
For compound 4 the middle estimate is 3 percentage points above the measured one; low and high end bracket the measured number.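

In this assay, putting hydrogen in place of one methoxy group on the core of compound 1 gives a number 1 percentage points lower from compound 1 to compound 4 (within the scatter). So the swap reads the same on both cores as far as this measurement can tell, and the step seen on one core gave a fair guide to the step on the other: the same change on two cores in this assay, a number 2 percentage points higher (within the scatter) from compound 2 to compound 3 and a number 1 percentage points lower (within the scatter) from compound 1 to compound 4, 3 percentage points apart, within the scatter of two such steps. This does not show that the methoxy group is without any effect, nor that the swap would behave this way on further cores, for it rests on just two pairs of compounds, each read at a single concentration, which gives the size of the effect at that concentration and not a potency.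

The compounds shown leave open how other groups would read on this aromatic carbon, such as a hydroxyl group, an ethoxy group, a longer chain or a fluorine atom, as only methoxy and hydrogen are compared there. They also leave open whether the swap would still read alike at higher concentrations, or on a core carrying an amide in place of the amino group of compound 4.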